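Furan for thiophene on the saturated ring carbon of compound 3

The compounds below may be only part of what the source reports. "The series", "measured", "known", "first", "only" and "open" are said of these compounds alone.

The series shares a fused core carrying a trimethoxyphenyl group; compound 1 `COc1cc(-c2nnc3n2NC(c2ccco2)C(C(=O)c2ccc(F)c(F)c2)S3)cc(OC)c1OC` and compound 2 `COc1cc(-c2nnc3n2NC(c2ccco2)C(C(=O)c2ccc(Cl)cc2)S3)cc(OC)c1OC` differ only in the aryl group on the carbonyl carbon. In a functional assay on HepG2 cells (Homo sapiens) for cytotoxicity, read by MTT assay, with a stated time of 48 h (on this read-out lower numbers stand for stronger inhibition and higher numbers for weaker inhibition), compound 1 gives 52400 nM and compound 2 gives 78600 nM; the step of a 1.5-fold higher number from compound 1 to compound 2 (0.18 log units; within the scatter) is within the scatter. Compound 3 `COc1cc(C(=O)C2Sc3nnc(-c4cc(OC)c(OC)c(OC)c4)n3NC2c2cccs2)cc(OC)c1OC` carries thiophen-2-yl on the saturated ring carbon and a trimethoxyphenyl group on the carbonyl carbon. For compound 3 only a limit is known, > 100000 nM, which is the limit of this assay rather than a number (the limit of > 100000 nM in this assay, at which 1 of the 3 values shown sits). Compound 4 `COc1cc(C(=O)C2Sc3nnc(-c4cc(OC)c(OC)c(OC)c4)n3NC2c2ccco2)cc(OC)c1OC` is not yet measured; it differs from compound 3 by furan-2-yl in place of thiophen-2-yl on a saturated ring carbon. Within the data shown here, no measured step touches the saturated ring carbon, so the only measured step, a 1.5-fold higher number from compound 1 to compound 2 (0.18 log units; within the scatter), concerns a different place and does not bear on this change. Compound 4 is therefore expected to remain weak, near 90000 nM with a range of 40000 nM to 200000 nM, and the step of an at least 1.1-fold lower number from compound 3 to compound 4 (0.04 log units; that floor lies within the scatter) is estimated to lie within the scatter, with a fair chance that only a limit is reported.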

Compound 4, half-maximal inhibitory concentration: > 100000 nM
Compound 4 gave a limit, no number (the forecaster's own chance of this, stated with the estimate: 55%); middle value at least 1.1-fold (0.04 log units) away from the limit.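

In this assay compound 4 gives > 100000 nM, which is a limit of the assay and not a number. The step for furan-2-yl in place of thiophen-2-yl on the saturated ring carbon cannot be read, and both compounds of that pair sit at the same limit: the limit of > 100000 nM in this assay, at which 2 of the 4 values shown sit. With furan-2-yl held fixed, the change on the carbonyl carbon to 3,4,5-trimethoxyphenyl gives an at least 1.2-fold higher number from compound 2 to compound 4 (0.10 log units; that floor lies within the scatter) and an at least 1.9-fold higher number from compound 1 to compound 4 (0.28 log units; that floor lies within the scatter), so both floors stay within the scatter and neither step shows a real loss.

As far as these compounds go, what thiophen-2-yl does alongside 4-chlorophenyl or 3,4-difluorophenyl on the carbonyl carbon stays open. So does whether an amine or a carboxylic acid on the saturated ring carbon would give a readable value.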